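Ortho substituent variation on the benzylidene piperidine arm

A few compounds are considered here, and "the series" means these few. Any claim that something is new, unique, unknown or untested is made for them only; others in the source may bear on it.

Measured compounds:
compound 1, `CN(C)CC[C@H](CSc1ccccc1)Nc1ccc(S(=O)(=O)NC(=O)c2ccc(N3CCC(=Cc4ccc(F)cc4)CC3)cc2)cc1[N+](=O)[O-]`, 600 nM
compound 2, `CN(C)CC[C@H](CSc1ccccc1)Nc1ccc(S(=O)(=O)NC(=O)c2ccc(N3CCC(=Cc4ccccc4Cl)CC3)cc2)cc1[N+](=O)[O-]`, 450 nM
compound 3, `CN(C)CC[C@H](CSc1ccccc1)Nc1ccc(S(=O)(=O)NC(=O)c2ccc(N3CCC(=Cc4ccccc4C(F)(F)F)CC3)cc2)cc1[N+](=O)[O-]`, 210 nM

In a functional assay (FL5.12 cells, Mus musculus) with Apoptosis regulator Bcl-2 (Homo sapiens) as the target (on this read-out higher numbers stand for an effect only at larger amounts of compound and lower numbers for an effect already at smaller amounts), compound 3 stands at the lowest of the three numbers; its nearest neighbour is compound 2, and the step of a 2.1-fold lower number from compound 2 to compound 3 (0.33 log units; beyond the scatter) lies beyond the scatter, as does a 2.9-fold lower number from compound 1 to compound 3 (0.46 log units; beyond the scatter). The step of a 1.3-fold lower number from compound 1 to compound 2 (0.12 log units; within the scatter) is within the scatter, so compound 1 and compound 2 are not separated.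

Compound 4, `COc1ccccc1C=C1CCN(c2ccc(C(=O)NS(=O)(=O)c3ccc(N[C@H](CCN(C)C)CSc4ccccc4)c([N+](=O)[O-])c3)cc2)CC1`, has not been measured. It differs from compound 3 by methoxy in place of trifluoromethyl on an aromatic carbon.

Among the compounds with values here, two measured steps bear on this position. a 2.1-fold lower number from compound 2 to compound 3 (0.33 log units; beyond the scatter) shows that putting trifluoromethyl in place of chloro lowered the number modestly; a 2.9-fold lower number from compound 1 to compound 3 (0.46 log units; beyond the scatter) shows the same direction for the trifluoromethyl compound against the fluorophenyl compound. Within the data shown here, no measured compound carries methoxy at any position, so the effect of the entering group itself is unknown; what is known is that removing trifluoromethyl takes away the group that gave the lowest number.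

For compound 4 a modest rise in this assay relative to compound 3 is therefore expected, about the size of the step it reverses, giving a 2.0-fold higher number from compound 3 to compound 4 (0.30 log units; within the scatter) as the expected change. The estimate for compound 4 is 420 nM, with a range of 150 nM to 1200 nM.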

Compound 4, half-maximal effective concentration: 250 nM
For compound 4 the middle estimate is 1.7-fold (0.23 log units) above the measured one, within the range that was stated.
By their numbers in this assay, from the lowest: compounds 3, 4, 2 and 1 (each within the scatter of the next, the first and the last beyond it).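

In this assay methoxy in place of trifluoromethyl on this aromatic carbon gives a 1.2-fold higher number from compound 3 to compound 4 (0.08 log units; within the scatter) and the two compounds are not separated, so a number at the level of compound 3 is not tied to trifluoromethyl alone. Against chloro on the same carbon the reading is a 1.8-fold lower number from compound 2 to compound 4 (0.26 log units; within the scatter) and this pair is not separated either, which leaves compound 4 overlapping both compound 2 and compound 3 although those two are separated from each other. A gap appears only against the 4-fluorophenyl compound, with a 2.4-fold lower number from compound 1 to compound 4 (0.38 log units; beyond the scatter) and compound 4 matches compound 3 in being separated from compound 1, while compound 2 goes against any general reading that a group at this place sets a compound apart from compound 1.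

The compounds shown leave open how an amine, a carboxylic acid or a longer chain such as ethoxy on this aromatic carbon would read in this assay and, with compound 1 differing in both group and place, what the fluoro group alone contributes. Nothing at hand accounts for any of these steps.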